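This account rests on a few compounds, and the source may have more. Where it says the series, first, only, none or still open, it means among the compounds named here.

Compound 1 `COc1cc(/C=C/c2nnc(NC(=O)c3ccc(Br)cc3)s2)c(Br)c(OC)c1OC`: 160 nM
Compound 2 `COc1cc(/C=C/c2nnc(NC(=O)c3cccc(F)c3)s2)c(Br)c(OC)c1OC`: 80 nM

Both values come from a functional assay on A549 cells (Homo sapiens) for antiproliferative activity, read by MTT assay, with a stated time of 48 h; a higher number here means a weaker inhibitor, a lower number a stronger inhibitor. Only these two compounds have been measured, and they differ in the group on the carbonyl carbon. The measured step is a 2.0-fold lower number from compound 1 to compound 2 (0.30 log units; within the scatter). Going by the values given here, compound 2 therefore has no firm rank: its 80 nM and the value of its only neighbour cannot be told apart in this assay.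

The next compound is compound 3 `COc1cc(/C=C/c2nnc(NC(=O)c3cccc(O)c3)s2)c(Br)c(OC)c1OC`. It keeps the core of compound 2 and carries hydroxy in place of fluoro on an aromatic carbon. Among the compounds with values here, no measured pair tests this swap directly. Within the data shown here, the one available step, from the 4-bromophenyl to the 3-fluorophenyl compound, involves a different change, so it offers only weak guidance. It does show that one change in this part of the molecule left this assay within the scatter, so a small step is the cautious expectation, with no firm direction. The expected step is a 1.5-fold higher number from compound 2 to compound 3 (0.18 log units; within the scatter). For compound 3 the estimated value is 120 nM, with an expected range from 35 nM to 400 nM.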

Compound 3, half-maximal inhibitory concentration: 120 nM
Beside the measured number, compound 3's estimate shows no gap at the digits printed; low and high end bracket the measured number.
By their numbers in this assay, from the lowest: compounds 2, 3 and 1 (each within the scatter of the next).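

In this assay, hydroxy in place of fluoro gives a 1.5-fold higher number from compound 2 to compound 3 (0.18 log units; within the scatter) and so adds a first direct test at this spot on the ring, meta to a large group. A group with a hydrogen-bond donor and acceptor replaces one with neither, and the assay cannot tell the two compounds apart. The 3-hydroxyphenyl group in place of 4-bromophenyl gives a 1.3-fold lower number from compound 1 to compound 3 (0.12 log units; within the scatter) and reads the same way, so all three groups on the carbonyl carbon now sit within the scatter of one another, and no measurement here offers a reason for this result.

On these data alone, what remains open is whether any group at this spot can move the number beyond the scatter, and an amine, a carboxylic acid or a longer chain such as ethoxy would test that with a larger change than the one seen here. As far as these compounds go, the step between the 4-bromophenyl and 3-hydroxyphenyl compounds also changes both the group and where it sits on the ring, so the effect of each on its own remains unknown.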